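The compounds below may be only part of what the source reports. "The series", "measured", "known", "first", "only" and "open" are said of these compounds alone.

Measured compounds:
Compound 1, `CCOC(=O)C1=Cc2ccccc2OC1(OCc1cn(-c2cccc(OC)c2)nn1)C(F)(F)F`, in a functional assay on A549 cells (Homo sapiens) for inhibition, read by MTT assay, with a stated time of 24 h (a higher number here means a weaker inhibitor, a lower number a stronger inhibitor), gives > 150000 nM, which is a limit of the assay and not a number.
Compound 2, `CCOC(=O)C1=Cc2ccccc2OC1(OCc1cn(CC(=O)Nc2ccc(I)cc2Cl)nn1)C(F)(F)F`, in this assay gives 22300 nM.

Among the compounds with values here, compound 2 therefore holds the only number in this assay; the other value shown is a limit (the limit of > 150000 nM in this assay, at which 1 of the 2 values shown sits). Within the data shown here, the only measured step, an at least 6.7-fold lower number from compound 1 to compound 2 (0.82 log units; beyond the scatter), exchanged the whole substituent on the aromatic nitrogen, 3-methoxyphenyl for ((2-chloro-4-iodophenyl)carbamoyl)methyl. Compound 3, `CCOC(=O)C1=Cc2ccccc2OC1(OCc1cn(CC(=O)Nc2cccc(F)c2)nn1)C(F)(F)F`, keeps that carbamoylmethyl arm and differs from compound 2 only in 3-fluorophenyl in place of 2-chloro-4-iodophenyl on an amide-type nitrogen. Among the measured compounds shown here, no measured step changes the ring on the amide nitrogen alone, so the step from compound 1 to compound 2 bears on this change only loosely: it shows that the carbamoylmethyl arm goes with a clearly stronger inhibition than the 3-methoxyphenyl. Compound 3 is expected to remain closer to compound 2 than to compound 1, with a modest rise in number, estimated as a 1.8-fold higher number from compound 2 to compound 3 (0.25 log units; within the scatter). The estimate for compound 3 in this assay is 40000 nM, between 15000 nM and 120000 nM.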

Compound 3, half-maximal inhibitory concentration: > 150000 nM
Compound 3 gave a limit, no number; the forecaster's own chance of this, stated with the estimate: 25%; middle value at least 3.7-fold (0.57 log units) from the limit.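

With the carbamoylmethyl arm held fixed, the ring on the amide-type nitrogen proves decisive in this assay: exchanging 2-chloro-4-iodophenyl for 3-fluorophenyl gives an at least 6.7-fold higher number from compound 2 to compound 3 (0.82 log units; beyond the scatter), so the arm alone does not carry the inhibition. Within the data shown here, of the two compounds with this arm, only the one with 2-chloro-4-iodophenyl gives a number. The result for compound 3 is a limit of the assay and not a number, as is that for compound 1, so the step between them cannot be read: the limit of > 150000 nM in this assay, at which 2 of the 3 values shown sit.

The compounds shown leave open whether the chlorine, the iodine or both together go with the lower number, since the two rings differ in all their substituents. They also leave open how a plain phenyl, or a phenyl carrying an amine or a carboxylic acid, on the amide-type nitrogen would read in this assay.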